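Phenyl in Place of Dihydroxyphenyl: Expected Cytotoxicity

A few compounds are considered here, and "the series" means these few. Any claim that something is new, unique, unknown or untested is made for them only; others in the source may bear on it.

Three compounds have been measured in an ADME assay on HEL cells (Homo sapiens) for cytotoxicity; on this read-out lower numbers stand for higher toxicity in this test and higher numbers for lower toxicity in this test:

Compound 1 `COc1ccc(/C=N/NC(=O)COc2cccc3ccccc23)cc1OC`: compound 1 gives 52.6 ug/mL
Compound 2 `C/C(=N\NC(=O)COc1cccc2ccccc12)c1ccc(O)cc1O`: compound 2 gives 74.8 ug/mL
Compound 3 `O=C(COc1cccc2ccccc12)N/N=C/c1ccc([N+](=O)[O-])cc1`: compound 3 gives 14.2 ug/mL

Compound 2 holds the highest of the three numbers. Compound 1 lies within the usual scatter of it, so the two cannot be told apart on this read-out. Compound 3 sits well beyond the scatter with a clearly lower number, that is, it is more toxic in this test than compound 2.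

Compound 4 `C/C(=N\NC(=O)COc1cccc2ccccc12)c1ccccc1` has not yet been measured in this assay. It differs from compound 2 in one place: phenyl in place of 2,4-dihydroxyphenyl on a carbon with a double bond to nitrogen. Going by the values given here, no two measured compounds differ in only one place, so there is no measured step of this kind to lean on. The three measured numbers lie in a fairly narrow band, and the change swaps one aromatic ring for another of the same size. The step expected is therefore small, at most a mild move towards a lower number, and quite possibly none beyond the scatter.

Compound 4 is expected to give about 55 ug/mL, with a range from 25 ug/mL to 110 ug/mL. This estimate means an expected step of a 1.4-fold lower number from compound 2 to compound 4 (0.13 log units; within the scatter).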

Compound 4, half-maximal cytotoxic concentration: 20 ug/mL
Compound 4: the middle estimate sits 2.8-fold (0.44 log units) above what was measured; measured number below the stated range.
By their numbers in this assay, from the lowest: compounds 3 and 4 (each within the scatter of the next); then compounds 1 and 2 (each within the scatter of the next).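

In this assay, going by these compounds alone, the swap at this position gives a 3.7-fold lower number from compound 2 to compound 4 (0.57 log units; beyond the scatter), the first step that can be read as a change in one place. It shows that the group on this carbon with a double bond to nitrogen is not a bystander: the ring stays the same size, yet losing the hydrogen-bond donors and acceptors counted on 2,4-dihydroxyphenyl, together with its two oxygen atoms, goes with higher toxicity in this test. No measurement here explains why the number falls.

From the compounds shown here alone, it remains open whether a single hydroxyl group on the phenyl ring would restore the higher number, and whether an amine or a carboxylic acid on that ring would do the same. Compound 1 and compound 3 each differ from compound 4 in more than one place, so they cannot show whether the same step would appear on a carbon that lacks the methyl group.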